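Trading ethyl for methoxy on a soluble compound

A few compounds are considered here, and "the series" means these few. Any claim that something is new, unique, unknown or untested is made for them only; others in the source may bear on it.

In a physicochemical assay for solubility, in phosphate buffer, measured as kinetic solubility (on this read-out higher numbers stand for higher solubility and lower numbers for lower solubility), compound 1 `CCCN(CC1CCOCC1)c1c(CC)nn2c(-c3c(OC)cc(COC)cc3OC)cccc12` gives 3100 nM, compound 2 `CCc1nn2c(-c3c(OC)cccc3OC)cccc2c1N(CC1CCOCC1)CC1CC1` gives 3300 nM and compound 3 `CCc1nn2c(-c3c(OC)cc(COC)cc3OC)cccc2c1N(CC1CCOCC1)CC1CC1` gives 4800 nM. Compound 3 lies within the scatter of both of the others, so it stands level with them. Compound 4 `COCc1cc(OC)c(-c2cccc3c(N(CC4CCOCC4)CC4CC4)c(OC)nn23)c(OC)c1` has not yet been measured. It differs from compound 3 by methoxy in place of ethyl on an aromatic carbon.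

Two measured steps lead to compound 3. Cyclopropyl in place of ethyl on a saturated chain carbon bound to a nitrogen on an aromatic ring gave a 1.5-fold higher number from compound 1 to compound 3 (0.19 log units; within the scatter). Methoxymethyl in place of hydrogen on an aromatic carbon gave a 1.5-fold higher number from compound 2 to compound 3 (0.16 log units; within the scatter). Among the measured compounds shown here, both steps are small, but both changes were made elsewhere in the molecule, and no measured pair tests this swap directly. No shift beyond the scatter is therefore expected in this assay, though with real uncertainty. The estimate is a 1.1-fold lower number from compound 3 to compound 4 (0.03 log units; within the scatter). For compound 4 the expected value is 4500 nM, with an estimated range of 2000 nM to 10000 nM.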

Compound 4, solubility: 5500 nM
Compound 4: middle estimate off by 1.2-fold (0.09 log units), on the low side; low and high end bracket the measured number.
By their numbers in this assay, from the lowest: compounds 1, 2, 3 and 4 (each within the scatter of the next).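

Putting methoxy in place of ethyl on this aromatic carbon of the five-membered ring, next to the ring nitrogen, gave a 1.1-fold higher number from compound 3 to compound 4 (0.06 log units; within the scatter) in this assay and is the only direct test of this position among the compounds shown. The two groups have the same count of heavy atoms, but methoxy brings one hydrogen-bond acceptor that ethyl lacks, and the numbers for the two compounds still stand level. Nothing measured here explains this result.

As far as these compounds go, whether a quite different group at this position, such as an amine or a longer chain, would move the number beyond the scatter remains open. Also open, from the compounds shown here alone, is whether the same swap would read alike with the other groups carried by compound 1 and compound 2.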